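Diethylamine to Piperidine on a Hexyl Chain

This account rests on a few compounds, and the source may have more. Where it says the series, first, only, none or still open, it means among the compounds named here.

Measured compounds:
Compound 1, `COc1cc(/C=C/C(=O)Nc2ccccc2)ccc1OCCCN(C)C`, gives 1.55 in a physicochemical assay for lipophilicity, using the shake flask method, measured as octanol-water partition, at pH 7.4; on this read-out lower numbers stand for lower lipophilicity and higher numbers for higher lipophilicity.
Compound 2, `COc1cc(/C=C/C(=O)Nc2ccccc2)ccc1OCCCCCCN1CCCCC1`, gives 1.77 in this assay.
Compound 3, `CCOC(=O)/C=C/c1ccc(OCCCCCCN(CC)CC)c(OC)c1`, gives 1.8 in this assay.

All three numbers sit close together. Compound 3 nominally tops the set, but its gaps to compound 2 and to compound 1 both lie within the scatter, so the three cannot be told apart in this assay.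

Compound 4, `CCOC(=O)/C=C/c1ccc(OCCCCCCN2CCCCC2)c(OC)c1`, is the next member. It differs from compound 3 by piperidin-1-yl in place of diethylamino on a saturated chain carbon, six bonds along the chain from an oxygen on an aromatic ring. For the measured compounds named here, only one measured step bears on this: a number 0.22 log units higher from compound 1 to compound 2 (within the scatter), where the amine was cyclised and the chain lengthened at once, and the result stayed within the scatter. The change from compound 3 to compound 4 is narrower, a ring closing over the two ethyl groups of the amine with the chain left as it is, so a step of comparable or smaller size is expected, with no direction beyond the scatter. The estimated step is a number 0.05 log units higher from compound 3 to compound 4 (within the scatter). Compound 4 is therefore expected to give 1.85 in this assay, within a range from 1.5 to 2.2.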

Compound 4, partition coefficient: 1.81
Estimate against measurement, compound 4: 0.04 log units above; the range from low to high includes it.
By their numbers in this assay, from the lowest: compounds 1, 2, 3 and 4 (each within the scatter of the next).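

In this assay, closing the two ethyl groups of the amine into a ring while the chain stays as it is gives a number 0.01 log units higher from compound 3 to compound 4 (within the scatter). This is the first step shown that touches the amine alone, piperidin-1-yl in place of diethylamino on a saturated chain carbon, six bonds along the chain from an oxygen on an aromatic ring, and on this read-out the pair cannot be told apart. A second exchange, ethoxy in place of anilino on a carbonyl carbon, gives a number 0.04 log units higher from compound 2 to compound 4 (within the scatter), so that pair cannot be told apart either, and nothing available here bears on why these numbers stay together.

As far as these compounds go, each of these steps rests on a single pair, so what a morpholin-4-yl or pyrrolidin-1-yl group would give on this chain carbon remains open, as does a carboxylic acid in place of the ethoxy group on the carbonyl carbon. Also open, from the compounds shown here alone, is whether piperidin-1-yl in place of diethylamino gives a similar step on a shorter chain such as propyl, or in an anilino compound.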